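The source may hold more compounds than are shown below. What is called first, only, known or untested is meant among the compounds shown, and "the series" means these compounds.

Measured compounds:
compound 1, `O=S(=O)(NCCNCc1cccc2ccccc12)c1cc(C(F)(F)F)cc(C(F)(F)F)c1`: 16000 nM
compound 2, `O=S(=O)(NCCCNCC1COc2ccccc2O1)c1cc(C(F)(F)F)cc(C(F)(F)F)c1`: 2200 nM

In a functional assay on HT-29 cells (Homo sapiens) for inhibition, read by MTT assay, with a stated time of 72 h (on this read-out higher numbers stand for weaker inhibition of growth and lower numbers for stronger inhibition of growth), compound 2 gives 2200 nM, the lowest of the two numbers measured. Compound 1 gives 16000 nM in this assay, a higher number that lies beyond the usual scatter, so compound 2 is the stronger grower-inhibitor of the pair.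

Compound 3, `COc1cccc(CNCCCNS(=O)(=O)c2cc(C(F)(F)F)cc(C(F)(F)F)c2)c1`, has not yet been measured. It differs from compound 2 in one place:
3-methoxyphenyl in place of 2,3-dihydro-1,4-benzodioxin-2-yl on a saturated chain carbon bound to an amine nitrogen
Among the measured compounds shown here, nothing measured here shows what this change does, and no comparable step between two measured compounds exists. The account therefore expects only a moderate step, if any, from compound 2 to compound 3 in this assay, more likely toward a higher number than a lower one: a 2.0-fold higher number from compound 2 to compound 3 (0.31 log units; beyond the scatter). Compound 3 is estimated at 4500 nM in this assay, within a range from 1500 nM to 13000 nM.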

Compound 3, concentration for 50% growth inhibition: 10000 nM
Estimate against measurement, compound 3: 2.2-fold (0.35 log units) below; measured number inside the range.
By their numbers in this assay, from the lowest: compound 2; then compounds 3 and 1 (each within the scatter of the next).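

In this assay, placing 3-methoxyphenyl on the saturated chain carbon bound to an amine nitrogen, in place of 2,3-dihydro-1,4-benzodioxin-2-yl, gives a 4.5-fold higher number from compound 2 to compound 3 (0.66 log units; beyond the scatter). Among the compounds shown here, this is the first readable step at this place, and it shows that growth inhibition depends on the group carried there, with 2,3-dihydro-1,4-benzodioxin-2-yl the better of these two. The change removes the six-membered non-aromatic ring and one hydrogen-bond acceptor together, and no measured evidence is available to account for the step.

Still open is which part of the change matters, since the compounds shown do not include a plain phenyl group or a pyridine ring at this place. Also open, going by these compounds, is whether the same step would appear with a longer chain.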